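A few compounds are considered here, and "the series" means these few. Any claim that something is new, unique, unknown or untested is made for them only; others in the source may bear on it.

Measured in an ADME assay on Vero 76 cells (Chlorocebus sabaeus) for cytotoxicity, read by MTT assay, with a stated time of 96 h; on this read-out lower numbers stand for higher toxicity in this test and higher numbers for lower toxicity in this test:
compound 1 `FC(F)(F)c1ccc(NCc2cn(-c3ccccc3)nc2-c2ccc(C(F)(F)F)cc2)cc1`: 26000 nM
compound 2 `FC(F)(F)c1ccc(NCc2cn(-c3ccccc3)nc2-c2ccccc2)cc1`: 17000 nM
compound 3 `FC(F)(F)c1ccc(NCc2cn(-c3ccccc3)nc2-c2ccc(Cl)cc2)cc1`: 18000 nM

The three values lie within the scatter of one another. Compound 3 stands at 18000 nM, and both of its steps stay within the scatter: a 1.1-fold higher number from compound 2 to compound 3 (0.02 log units; within the scatter) and a 1.4-fold lower number from compound 1 to compound 3 (0.16 log units; within the scatter).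

Compound 4 `Cc1ccc(-c2nn(-c3ccccc3)cc2CNc2ccc(C(F)(F)F)cc2)cc1` has no value yet. Its change from compound 3 is methyl in place of chloro on an aromatic carbon, that is, 4-chlorophenyl to 4-methylphenyl.

Going by the values given here, no compound with methyl at this place has been measured, so the evidence is indirect. Among the compounds with values here, the steps that bear on the change are the two above and a 1.5-fold lower number from compound 1 to compound 2 (0.18 log units; within the scatter), all made at this same place and all within the scatter. Hydrogen, chloro and trifluoromethyl there are not separated in this assay. These three compounds give no direction for methyl, so no step beyond the scatter is expected. The estimated step is a 1.1-fold higher number from compound 3 to compound 4 (0.02 log units; within the scatter). For compound 4 the expected value is 19000 nM, with the measurement estimated to fall between 11000 nM and 32000 nM.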

Compound 4, half-maximal cytotoxic concentration: 45000 nM
The estimate for compound 4 lay 2.4-fold (0.37 log units) below the measured number, outside the stated range (above it).
By their numbers in this assay, from the lowest: compounds 2, 3, 1 and 4 (each within the scatter of the next, the first and the last beyond it).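

In this assay, going by these compounds alone, this position is no longer flat: methyl in place of chloro gives a 2.5-fold higher number from compound 3 to compound 4 (0.40 log units; beyond the scatter) and methyl in place of hydrogen gives a 2.6-fold higher number from compound 2 to compound 4 (0.42 log units; beyond the scatter) as the first steps at this place to lie beyond the scatter, both modest in size. Methyl in place of trifluoromethyl gives a 1.7-fold higher number from compound 1 to compound 4 (0.24 log units; within the scatter) and stays within the scatter, so methyl separates from chloro and hydrogen but not from trifluoromethyl, and compound 1 and compound 4 cannot be ordered; the pattern therefore rests on two steps only, with compound 1 as the exception. Nothing at hand accounts for this separation of methyl from chloro and hydrogen.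

Going by these compounds, whether the higher number in this test belongs to methyl alone, or also appears with a longer chain such as ethyl, or with methoxy or an amine at the same place, stays open. A single methyl compound also leaves open whether the step from chloro to methyl would hold with other groups on the rest of the shared core.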